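A few compounds are considered here, and "the series" means these few. Any claim that something is new, unique, unknown or untested is made for them only; others in the source may bear on it.

Compound 1 `COc1cccc(OC(c2ccc(C(F)(F)F)cc2)C2CCN(C(C)CCNC(=O)c3c(Cl)cncc3Cl)CC2)n1` gives 32700 nM in an ADME assay on PBMC cells (Homo sapiens) for cytotoxicity; on this read-out lower numbers stand for higher toxicity in this test and higher numbers for lower toxicity in this test.
Compound 2 `CC(CCNC(=O)c1c(Cl)cncc1Cl)N1CCC(C(Oc2ncccc2Cl)c2ccc(C(F)(F)F)cc2)CC1` gives 16700 nM in this assay.
Compound 3 `CCO/N=C(/c1ccc(Br)cc1)C1CCN(C(C)CCN(C)C(=O)c2c(C)cc[n+]([O-])c2C)CC1` gives only a limit of the test, > 182000 nM, in this assay.

Among the two numbers in this assay, compound 2 stands lowest, with compound 1 nearest through the step of a 2.0-fold lower number from compound 1 to compound 2 (0.29 log units; within the scatter). The result for compound 3 is a limit and not a number (the limit of > 182000 nM in this assay, at which 1 of the 3 values shown sits). Compound 4 `CC(CCNC(=O)c1c(Cl)cncc1Cl)N1CCC(C(Oc2ccc(C(F)(F)F)cc2)c2ccc(C(F)(F)F)cc2)CC1` differs from compound 2 in one place: 4-(trifluoromethyl)phenyl in place of 3-chloropyridin-2-yl on an oxygen on a saturated carbon. Within the data shown here, the only measured step at this oxygen is the one from compound 1 to compound 2, and it stayed within the scatter. The step of a 1.3-fold lower number from compound 2 to compound 4 (0.11 log units; within the scatter) is therefore expected to be small, without a direction that the data would support. The value of compound 4 is estimated at 13000 nM, within a range from 5000 nM to 35000 nM.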

Compound 4, half-maximal cytotoxic concentration: 3100 nM
The estimate for compound 4 lay 4.2-fold (0.62 log units) above the measured number; the measured number lies below the stated range.
By their numbers in this assay, from the lowest: compound 4; then compounds 2 and 1 (each within the scatter of the next). At a limit, above all of these: compound 3.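

Unlike the exchange between the two pyridines, placing 4-(trifluoromethyl)phenyl on this oxygen moves the number in this assay beyond the scatter, with a 5.4-fold lower number from compound 2 to compound 4 (0.73 log units; beyond the scatter) and an 11-fold lower number from compound 1 to compound 4 (1.02 log units; beyond the scatter). The group on this oxygen therefore matters in this test, and the carbon-only ring goes with higher toxicity than either pyridine shown. Nothing given here bears on a cause for these steps.

As far as these compounds go, the ring nitrogen leaves and the trifluoromethyl group enters in the same change, so their separate contributions remain open. Also open, from the compounds shown here alone, is whether a phenyl ring carrying a nitrile or an amine on this oxygen would resemble compound 4 or the pyridines.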